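This account rests on a few compounds, and the source may have more. Where it says the series, first, only, none or still open, it means among the compounds named here.

Measured compounds:
compound 1, `CCC(CC)CNc1c(C(N)=O)cnc2ccc(C#N)cc12`, 74 uL/min
compound 2, `NC(=O)c1cnc2ccc(-c3cccnc3)cc2c1NC1CCCC1`, 65 uL/min

Two compounds carry a number in an ADME assay on cells (Hepatocyte, Rattus norvegicus) for metabolic stability, with a stated time of 90 min (on this read-out higher numbers stand for fast clearance and lower numbers for slow clearance), so far. Compound 1 gives 74 uL/min and compound 2 gives 65 uL/min; the two numbers lie within the scatter of each other, so neither can be set apart from the other on this read-out, and both sit in the middle range of what this assay reports.

Compound 3, `C[C@@H](Nc1c(C(N)=O)cnc2ccc(-c3cccnc3)cc12)C1CCOCC1`, has not been run in this assay. It differs from compound 2 in one place: 1-(oxan-4-yl)ethyl in place of cyclopentyl on a nitrogen on an aromatic ring. Going by the values given here, no pair of measured compounds shows a step of this kind, so there is no measured step to lean on; the only guide is the position of compound 2.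

For compound 3 the expectation is a small change, if any, in this assay, with the number for compound 3 estimated at 50 uL/min within a range of 25 uL/min to 100 uL/min. The step that this estimate means, a 1.3-fold lower number from compound 2 to compound 3 (0.11 log units; within the scatter), is expected to stay within the usual scatter of repeated measurements.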

Compound 3, intrinsic clearance in a liver preparation (reported as CLH), per the amount of preparation that the assay uses: 46 uL/min
Compound 3: the middle estimate sits 1.1-fold (0.04 log units) above what was measured; the range from low to high includes it.
By their numbers in this assay, from the lowest: compounds 3, 2 and 1 (each within the scatter of the next).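

In this assay, going by these compounds alone, replacing cyclopentyl with 1-(oxan-4-yl)ethyl on the nitrogen on an aromatic ring gives a 1.4-fold lower number from compound 2 to compound 3 (0.15 log units; within the scatter), the first measured step at this position, and it lies within the scatter. Within the data shown here, the entering group has 8 heavy atoms against 5, a six-membered non-aromatic ring with 1 hetero atom, 1 hydrogen-bond acceptor against 0, and 1 defined stereocentre, yet together these differences produce no step that can be told from repeated measurement on this read-out. No measured data on the compounds bear on what lies behind this result.

The single step changes the ring, the ring oxygen, the ethyl link and the stereocentre at once, so the compounds shown leave open what each part contributes and how the opposite configuration at the stereocentre would read. Also open, going by these compounds, is how this assay would respond to an amine or a carboxylic acid on the group at this nitrogen; both groups compared here carry no net charge.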